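This account rests on a few compounds, and the source may have more. Where it says the series, first, only, none or still open, it means among the compounds named here.

Working notes on the series. Compound 1 `CN1CCc2nc(C#Cc3ccc(Cl)cc3)ccc2C1=O` gives 6150 nM in an assay on HEK293 cells for displacement of a labelled ligand from metabotropic glutamate receptor 5 (Homo sapiens), with a stated time of 2 h; on this read-out higher numbers stand for weaker inhibition and lower numbers for stronger inhibition. Compound 2 `O=C1c2ccc(C#Cc3ccccc3)nc2CCN1C1CCCC1` gives 890 nM in this assay. For compound 3 `O=C1c2ccc(C#Cc3ccccc3Cl)nc2CCN1C1CCCC1` the assay reports only a limit, > 32000 nM in this assay; compound 3 therefore stands at the weak end of the values shown, at the limit of > 32000 nM in this assay, at which 1 of the 3 values shown sits. Going by the values given here, the one measured step, an at least 35-fold higher number from compound 2 to compound 3 (1.55 log units; beyond the scatter), is large and beyond the scatter. Compound 4 `O=C1c2ccc(C#Cc3ccc(Cl)cc3)nc2CCN1C1CCCC1` differs from compound 3 by 4-chlorophenyl in place of 2-chlorophenyl on a triple-bonded carbon, so the change moves the chlorine rather than removing it. Among the compounds with values here, no measured step covers this move; compound 1 carries the same 4-chlorophenyl with a different group on the amide nitrogen and gives 6150 nM, while compound 2 without chlorine gives 890 nM. Compound 4 is expected to land between those two, a step of an at least 12-fold lower number from compound 3 to compound 4 (1.10 log units; beyond the scatter) toward stronger inhibition. The estimate for compound 4 is 2500 nM, with a range from 600 nM to 10000 nM.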

Compound 4, inhibition constant: > 32000 nM
Compound 4 was reported as a limit; the forecaster's own chance of this, stated with the estimate: 5%; middle value at least 12-fold (1.10 log units) from the limit.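

Compound 4 is reported only as a limit, so in this assay the 4-chlorophenyl group sits at the weak end with the 2-chlorophenyl group, and the step between compound 3 and compound 4 cannot be read: the limit of > 32000 nM in this assay, at which 2 of the 4 values shown sit. Chloro in place of hydrogen gives an at least 35-fold higher number from compound 2 to compound 4 (1.55 log units; beyond the scatter) and so leaves neither chlorophenyl compound near compound 2. Cyclopentyl in place of methyl gives an at least 5.2-fold higher number from compound 1 to compound 4 (0.71 log units; beyond the scatter) with the 4-chlorophenyl group in place.

As far as these compounds go, whether a fluoro or methoxy group on the phenyl ring behaves like chloro stays open. So does the effect of an ethyl or isopropyl group on the amide nitrogen.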